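Rat microsomal clearance: benzothiazole to pyridine swap on compound 1

The source may report more compounds than this note shows. Statements on the series, on what has been measured and on what is new or still open speak of the compounds shown alone.

Measured so far in an ADME assay (liver) for metabolic stability, with Liver microsome (Rattus norvegicus) as the target, using microsomes; a lower number here means slower removal, a higher number faster removal of the compound:
- compound 1, `CN(C(=O)c1ccc2ncsc2c1)c1ccc(OCB2C=Cc3ccccc3N2)cc1`: 73.3 mL/min/kg
- compound 2, `CN(C(=O)c1ccc2ncsc2c1)c1ccc(OCc2ccc3ccccc3c2)cc1`: 48.3 mL/min/kg
- compound 3, `CN(C(=O)c1ccncc1)c1ccc(OCc2ccc3ccccc3c2)cc1`: 75 mL/min/kg

Compound 1 stands second highest of the three numbers; its nearest neighbour is compound 3, whose value sits with it inside the scatter, and compound 2 lies furthest off, with the step of a 1.5-fold lower number from compound 1 to compound 2 (0.18 log units; within the scatter) still within the scatter. Among the measured compounds shown here, no pair of these three is separated beyond the scatter.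

The unmeasured compound is compound 4, `CN(C(=O)c1ccncc1)c1ccc(OCB2C=Cc3ccccc3N2)cc1`. It differs from compound 1 by pyridin-4-yl in place of 1,3-benzothiazol-6-yl on a carbonyl carbon

For the measured compounds named here, one measured step bears directly on this change: a 1.6-fold higher number from compound 2 to compound 3 (0.19 log units; within the scatter), the same exchange on a carbonyl carbon carried out on the naphthalen-2-yl-bearing pair. That step was within the scatter. The same exchange on compound 1 is therefore expected to give a similar, modest move in the same direction, a 1.4-fold higher number from compound 1 to compound 4 (0.13 log units; within the scatter), which need not exceed the scatter.

Compound 4 is accordingly estimated at 100 mL/min/kg in this assay, with a range from 55 mL/min/kg to 180 mL/min/kg.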

Compound 4, clearance: 115 mL/min/kg
For compound 4 the middle estimate is 1.2-fold (0.06 log units) below the measured one; low and high end bracket the measured number.
By their numbers in this assay, from the lowest: compounds 2, 1, 3 and 4 (each within the scatter of the next, the first and the last beyond it).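

In this assay, pyridin-4-yl in place of 1,3-benzothiazol-6-yl on a carbonyl carbon gives a 1.6-fold higher number from compound 1 to compound 4 (0.20 log units; within the scatter) on the boron-containing group. The exchange can now be read on two cores, and the two steps agree: the same change on two cores in this assay, a 1.6-fold higher number (0.19 log units; within the scatter) from compound 2 to compound 3 and a 1.6-fold higher number (0.20 log units; within the scatter) from compound 1 to compound 4, 1.0-fold (0.00 log units) apart, within the scatter of two such steps. Each step alone stays within the scatter, so the new information is the agreement in direction and size on both cores, not the size of either step.

Only two groups are shown on this carbonyl carbon, so it remains open which part of the change goes with the step: the loss of the five-membered ring, the loss of sulfur or the different ring nitrogen. Phenyl or pyridin-3-yl at the same place would begin to separate these, and whether any group there gives a step beyond the scatter also remains open.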